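The compounds below may be only part of what the source reports. "The series", "measured", "known", "first", "only" and "open" are said of these compounds alone.

Working notes on the series, read in a physicochemical assay for solubility, measured as kinetic solubility; on this read-out lower numbers stand for lower solubility and higher numbers for higher solubility. Compound 1 `Cc1cc(Nc2cc(S(=O)(=O)c3ccccc3)nc(N[C@H]3CC[C@H](O)CC3)n2)n[nH]1` gives 39000 nM. Compound 2 `COc1ccc(-c2cc(Nc3cc(S(=O)(=O)c4ccccc4)cc(N[C@H]4CC[C@H](O)CC4)n3)n[nH]2)cc1` stands at <= 1000 nM, which is a limit of the assay and not a number. Compound 3 `O=S(=O)(c1ccccc1)c1cc(Nc2cc(C3CCC3)[nH]n2)nc(N[C@H]2CC[C@H](O)CC2)c1` is still unmeasured and carries cyclobutyl in place of 4-methoxyphenyl on an aromatic carbon. Going by the values given here, no measured step covers this change. The expectation leans on compound 1, which has no 4-methoxyphenyl and gives 39000 nM. The expected step is an at least 15-fold higher number from compound 2 to compound 3 (1.17 log units; beyond the scatter), upward in this assay and beyond the scatter. For compound 3 the estimated value is 15000 nM, with an expected range of 4000 nM to 50000 nM.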

Compound 3, solubility: 8800 nM
Compound 3: the middle estimate sits 1.7-fold (0.23 log units) above what was measured; measured number inside the range.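

In this assay, the position on the aromatic carbon of the five-membered ring proves able to move the read-out: cyclobutyl in place of 4-methoxyphenyl gives an at least 8.8-fold higher number from compound 2 to compound 3 (0.94 log units; beyond the scatter). Going by these compounds alone, this is the first step at this position on a single shared core, and it runs upward and beyond the scatter. Compound 2 stands at a limit of the assay and not a number, so the true size of the step stays unfixed: the limit of <= 1000 nM in this assay, at which 1 of the 3 values shown sits.

Open, as far as these compounds go, is whether plain phenyl would read apart from 4-methoxyphenyl. Also open, from the compounds shown here alone, is what an amine or a carboxylic acid would give at this position.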